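Adding fluoro to a compound at the assay limit

The compounds below may be only part of what the source reports. "The series", "measured", "known", "first", "only" and "open" are said of these compounds alone.

Compound 1 `O=C1Nc2ccccc2/C1=C/c1ccc(-c2cn(-c3cccc(Cl)c3)nn2)cc1`: > 20000 nM
Compound 2 `N#Cc1cccc(-n2cc(-c3ccc(/C=C4\C(=O)Nc5ccccc54)cc3)nn2)c1`: > 20000 nM

In a functional assay on MKN-45 cells (Homo sapiens) for inhibition, read by CCK-8 assay, with a stated time of 24 h (a higher number here means a weaker inhibitor, a lower number a stronger inhibitor), compound 1 gives > 20000 nM, which is a limit and not a number. Compound 2 gives > 20000 nM, which is also a limit. This leaves one piece of evidence: the limit of > 20000 nM in this assay, at which 2 of the 2 values shown sit. Among the compounds with values here, the only measured step, a step that the two limits leave unreadable from compound 1 to compound 2, has no readable size and involves a different change, so it offers no guide. Compound 3 `O=C1Nc2ccc(F)cc2/C1=C/c1ccc(-c2cn(-c3cccc(Cl)c3)nn2)cc1` keeps the core of compound 1 and differs in one place: fluoro in place of hydrogen on an aromatic carbon. Within the data shown here, no measured step shows what fluoro in place of hydrogen does here, so no step beyond the scatter is expected. The estimate for compound 3 therefore stays near the limit of compound 1 at > 20000 nM. The expected step is a step that the limit leaves unreadable from compound 1 to compound 3. For compound 3 the expected value is 25000 nM, with an estimated range of 8000 nM to 60000 nM.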

Compound 3, half-maximal inhibitory concentration: 14100 nM
Compound 3: middle estimate off by 1.8-fold (0.25 log units), on the high side; the range from low to high includes it.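

Among the compounds shown, only compound 3 gives a number and not a limit in this assay: with fluoro in place of hydrogen on this aromatic carbon of the shared core, compound 3 gives 14100 nM. Set against compound 1, the result is an at least 1.4-fold lower number from compound 1 to compound 3 (0.15 log units; that floor lies within the scatter), which is a floor and not a full size. Compound 1 gives > 20000 nM, which is a limit and not a number.

From the compounds shown here alone, what a methoxy group or an amine would do on this same aromatic carbon stays open, so it cannot be said whether fluoro is special here or whether other groups at this place would give a similar value. Going by these compounds, the step from chloro to nitrile cannot be read, and whether fluoro at this place would also give a number on the core of compound 2 stays open.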